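Notes on losing the piperazine methyl

A few compounds are considered here, and "the series" means these few. Any claim that something is new, unique, unknown or untested is made for them only; others in the source may bear on it.

In an ADME assay on Caco-2 cells (Homo sapiens) for permeability (on this read-out lower numbers stand for lower permeability and higher numbers for higher permeability), compound 1 (`Cc1cn2cc(-c3cc4ccc(N5CCN(C)CC5)cc4c(=O)o3)nc2c(C)n1`) gives 1.2 10^-6 cm/s and stands lowest of the three measured compounds, with both gaps beyond the scatter. Compound 2 (`Cc1cn2cc(-c3cc4ccc(N5CCN(C)CC5)cc4oc3=O)nc2cn1`) gives 2.7 10^-6 cm/s on the same read-out. Compound 3 (`Cc1cn2nc(-c3cc(=O)n4cc(N5CCN(C)CC5)ccc4n3)cc2c(C)n1`) gives 7.5 10^-6 cm/s and stands highest.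

Compound 4 (`Cc1cn2cc(-c3cc4ccc(N5CCNCC5)cc4c(=O)o3)nc2c(C)n1`) has not yet been measured. It keeps the core of compound 1 and carries hydrogen in place of methyl on an amine nitrogen in a ring, so that 4-methylpiperazin-1-yl becomes piperazin-1-yl. Going by the values given here, all three measured compounds carry 4-methylpiperazin-1-yl, and no measured pair shows this change directly. The expectation is therefore loose: a modest downward step in this assay, of a size near the edge of the scatter. The estimated step is (a 2.0-fold lower number from compound 1 to compound 4 (0.30 log units; within the scatter)) and remains uncertain in size. For compound 4 the expected value is 0.6 10^-6 cm/s (estimated range 0.2 10^-6 cm/s to 1.5 10^-6 cm/s) in this assay once measured.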

Compound 4, apparent permeability: 4.4 10^-6 cm/s
Beside the measured number, compound 4's estimate is 7.3-fold (0.87 log units) below it, outside the stated range (above it).
By their numbers in this assay, from the lowest: compound 1; then compounds 2, 4 and 3 (each within the scatter of the next, the first and the last beyond it).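

In this assay, going by these compounds alone, hydrogen in place of methyl on the amine nitrogen of the ring gives a 3.7-fold higher number from compound 1 to compound 4 (0.56 log units; beyond the scatter) and so supplies the first direct reading of this change, as the earlier compounds all carry 4-methylpiperazin-1-yl. On the core of compound 1, the step from 4-methylpiperazin-1-yl to piperazin-1-yl therefore moves the number upward and beyond the scatter, so the methyl is not required for a higher number on this core. No measured evidence at hand accounts for the direction or size of this step.

This single pair cannot show whether the same step holds on the different cores of compound 2 and compound 3. From the compounds shown here alone, how an ethyl or an acetyl group on the same nitrogen would read also remains open.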